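Replacing the Sulfonyl Group with a Hexylcarbonyl Chain

A few compounds are considered here, and "the series" means these few. Any claim that something is new, unique, unknown or untested is made for them only; others in the source may bear on it.

Of the compounds shown here, three built on one shared core have been measured in a functional assay (Cavia porcellus) for antagonist activity at thromboxane A2 receptor (Homo sapiens); on this read-out lower numbers stand for tighter binding and higher numbers for weaker binding. Compound 1 `O=C(O)CC/C=C\C[C@@H]1CN(Cc2cccnc2)C[C@@H]1c1ccccc1O` gives 1580 nM, compound 2 `CC(C)C(=O)N1C[C@@H](C/C=C\CCC(=O)O)[C@@H](c2ccccc2O)C1` gives 200 nM, and compound 3 `O=C(O)CC/C=C\C[C@@H]1CN(S(=O)(=O)c2ccc(Cl)cc2)C[C@@H]1c1ccccc1O` gives 1 nM. Compound 3 stands lowest of the three numbers: a 1600-fold lower number from compound 1 to compound 3 (3.20 log units; beyond the scatter), and a 200-fold lower number from compound 2 to compound 3 (2.30 log units; beyond the scatter). The smaller step among the measured pairs, a 7.9-fold lower number from compound 1 to compound 2 (0.90 log units; beyond the scatter), shows that the two non-sulfonyl substituents on the ring nitrogen lie well apart from each other as well.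

Compound 4 `CCCCCCC(=O)N1C[C@@H](C/C=C\CCC(=O)O)[C@@H](c2ccccc2O)C1` differs from compound 3 in one place: hexylcarbonyl in place of (4-chlorophenyl)sulfonyl on an amine nitrogen in a ring. Among the compounds with values here, the step that bears on this change is the one between compound 2 and compound 3, where an acyl group on the same nitrogen gave way to the sulfonyl group and the number fell by a large amount. Compound 4 carries an acyl group again, a longer chain than in compound 2, so a large rise in this assay is expected, and the step from compound 3 to compound 4 is expected to be a 150-fold higher number from compound 3 to compound 4 (2.18 log units; beyond the scatter). Compound 4 is estimated at 150 nM, within a range from 30 nM to 800 nM.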

Compound 4, dissociation constant: 20 nM
The estimate for compound 4 lay 7.5-fold (0.88 log units) above the measured number; the measured number lies below the stated range.
By their numbers in this assay, from the lowest: compound 3; then compound 4; then compound 2; then compound 1.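

In this assay, an acyl group on this ring nitrogen can reach a low number without the sulfonyl group: lengthening it from isopropyl to hexyl on the carbonyl carbon gives a 10-fold lower number from compound 2 to compound 4 (1.00 log units; beyond the scatter) and so the group on the carbonyl carbon matters as well as the type of link to the nitrogen. Hexylcarbonyl still does not match (4-chlorophenyl)sulfonyl, with a 20-fold higher number from compound 3 to compound 4 (1.30 log units; beyond the scatter) as the remaining gap, which is smaller than a 200-fold lower number from compound 2 to compound 3 (2.30 log units; beyond the scatter) seen with the shorter acyl group. Against (pyridin-3-yl)methyl, the hexylcarbonyl group gives a 79-fold lower number from compound 1 to compound 4 (1.90 log units; beyond the scatter) and so keeps most of the advantage held by the sulfonyl compound.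

Isopropyl and hexyl alone cannot show whether the number follows chain length, and a butyl chain or a 4-chlorophenyl group on the carbonyl carbon would help separate the aryl ring from the sulfonyl link. No measurement available here explains these differences.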